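Adding One Fluoro to Compound 3

The source may hold more compounds than are shown below. What is called first, only, known or untested is meant among the compounds shown, and "the series" means these compounds.

Three amides of the shared core have been measured in a physicochemical assay for lipophilicity, read by HPLC; a higher number here means a more lipophilic compound, a lower number a more polar compound. Compound 1 `Cc1ccsc1C(=CCCN(C)C(CCO)C(=O)N1CCOCC1)c1sccc1C`, the morpholin-4-yl amide, gives 4.75. Compound 2 `Cc1ccsc1C(=CCCN(C)C(CCO)C(=O)NCc1ccc(F)cc1F)c1sccc1C`, which carries (2,4-difluorobenzyl)amino, gives 6.37. Compound 3 `Cc1ccsc1C(=CCCN(C)C(CCO)C(=O)NCc1ccccc1)c1sccc1C`, which carries benzylamino, gives 5.71. That places it second of the three, below compound 2 and above compound 1, with both gaps beyond the scatter.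

Compound 4 `Cc1ccsc1C(=CCCN(C)C(CCO)C(=O)NCc1ccc(F)cc1)c1sccc1C` has not yet been measured. It differs from compound 3 in one place: fluoro in place of hydrogen on an aromatic carbon. This change turns benzylamino into (4-fluorobenzyl)amino.

The closest evidence is a number 0.66 log units lower from compound 2 to compound 3 (beyond the scatter), a modest step beyond the scatter, with phenyl in place of 2,4-difluorophenyl. Read in reverse, it adds the full difluoro pattern, whereas compound 4 carries only the 4-fluoro part. The steps of a number 0.96 log units higher from compound 1 to compound 3 (beyond the scatter) and a number 1.62 log units higher from compound 1 to compound 2 (beyond the scatter) replace morpholin-4-yl and say less about this change. Among the measured compounds shown here, no single fluoro step has been measured, so a small rise, smaller than the reversed step, is expected, one that may not clear the scatter. The expected change is a number 0.29 log units higher from compound 3 to compound 4 (within the scatter). For compound 4 the estimated value is 6, with an expected range from 5.75 to 6.3.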

Compound 4, partition coefficient: 5.87
Compound 4: the middle estimate sits 0.13 log units above what was measured; the range from low to high includes it.
By their numbers in this assay, from the lowest: compound 1; then compounds 3 and 4 (each within the scatter of the next); then compound 2.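

In this assay, the single fluoro on an aromatic carbon, para to a large group, now has a direct reading: a number 0.16 log units higher from compound 3 to compound 4 (within the scatter) shows that this one change cannot be told apart from hydrogen. The difluoro pattern behaves differently, as a number 0.50 log units lower from compound 2 to compound 4 (beyond the scatter) is a step beyond the scatter, so the fluoro that (2,4-difluorobenzyl)amino carries in addition to the 4-fluoro makes a difference that the 4-fluoro alone does not. On the other side of the comparison, a number 1.12 log units higher from compound 1 to compound 4 (beyond the scatter) shows that (4-fluorobenzyl)amino, like benzylamino and (2,4-difluorobenzyl)amino, stands clearly apart from morpholin-4-yl on the carbonyl carbon, and this step is printed as large.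

The compounds shown leave open what (2-fluorobenzyl)amino would give on its own, and whether chloro, methyl or methoxy at the place of the 4-fluoro would move the number beyond the scatter. No evidence at hand accounts for the size of any of these steps.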